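From thiophen-2-yl to 3,4,5-trimethoxyphenyl: an expected growth inhibition

This account rests on a few compounds, and the source may have more. Where it says the series, first, only, none or still open, it means among the compounds named here.

In a functional assay on THP-1 cells (Homo sapiens) for inhibition, read by sulforhodamine B assay, with a stated time of 48 h, tested at 50 uM (on this read-out lower numbers stand for less inhibition of growth and higher numbers for more inhibition of growth at the one concentration tested), compound 2 (`COc1cc(/C=C/C(=O)/C=C/c2cccs2)ccc1OCc1cn(CCOc2cc(=O)oc3ccccc23)nn1`) gives 76% and stands second among the three measured compounds. Above it sits compound 1 (`COc1cc(/C=C/C(=O)/C=C/c2cccc3ccccc23)ccc1OCc1cn(CCOc2cc(=O)oc3ccccc23)nn1`) at 89% while compound 3 (`COc1cc(/C=C/C(=O)/C=C/c2cccs2)ccc1OCc1cn(CCCCCOc2cc(=O)oc3ccccc23)nn1`) gives the lowest number at 34% of the three.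

Compound 4 (`COc1cc(/C=C/C(=O)/C=C/c2cc(OC)c(OC)c(OC)c2)ccc1OCc1cn(CCOc2cc(=O)oc3ccccc23)nn1`) has no number yet. It differs from compound 2 by 3,4,5-trimethoxyphenyl in place of thiophen-2-yl on a double-bonded chain carbon bound to a double-bonded chain carbon with 3,4,5-trimethoxyphenyl in place of thiophen-2-yl on a double-bonded chain carbon bound to a double-bonded chain carbon.

Going by the values given here, only one measured step touches that place. It is a number 13 percentage points lower from compound 1 to compound 2 (beyond the scatter) when thiophen-2-yl replaces naphthalen-1-yl. Compound 3 also carries thiophen-2-yl, so it offers no comparison for swapping that group. Among the compounds with values here, one step is thin evidence, and no measured compound yet carries the new group. Within the data shown here, with compound 1 at 89% as the only guide, a small rise is expected in this assay rather than a fall, and it may well stay inside the scatter. The estimated change is a number 4 percentage points higher from compound 2 to compound 4 (within the scatter) for this swap. For compound 4 the expected value is 80% with an estimated range from 62% to 94% as the likely span.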

Compound 4, percent growth inhibition at one concentration: 99%
For compound 4 the middle estimate is 19 percentage points below the measured one; the whole stated range lies below it.
By their numbers in this assay, from the lowest: compound 3; then compound 2; then compounds 1 and 4 (each within the scatter of the next).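

In this assay, this place on the chain carbon proves to respond to more than one exchange: thiophen-2-yl is not the best group found here, and the trimethoxyphenyl ring gives a number 23 percentage points higher from compound 2 to compound 4 (beyond the scatter). The earlier compounds shown here showed only that naphthalen-1-yl gave a higher number than thiophen-2-yl, and now a second, quite different group does the same, while 3,4,5-trimethoxyphenyl and naphthalen-1-yl cannot be told apart, with a number 10 percentage points higher from compound 1 to compound 4 (within the scatter). So among these three groups thiophen-2-yl alone stands lower, but nothing shown here explains why the number changes with this exchange.

As far as these compounds go, whether all three methoxy groups are needed stays open, and a plain phenyl ring, or a phenyl ring carrying one methoxy group or a dimethylamino group, would help to separate the part played by the ring from that of its substituents. Also open, from the compounds shown here alone, is whether 3,4,5-trimethoxyphenyl would keep its high number on the longer chain of compound 3, and how compound 1 and compound 4 would compare at lower concentrations, which a test at one concentration cannot tell.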